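Solubility notes: fluoro in place of hydrogen, compound 3 to compound 4

The source may hold more compounds than are shown below. What is called first, only, known or untested is meant among the compounds shown, and "the series" means these compounds.

Measured so far in a physicochemical assay for solubility, at pH 7.4; on this read-out higher numbers stand for higher solubility and lower numbers for lower solubility:
compound 1 `O=C(CC(c1ccccc1)c1ccccc1)N1CCN(C(c2ccccc2)c2ccccc2Cl)CC1` gives 0.37 ug/mL
compound 2 `O=C(CC(c1ccccc1)c1ccccc1)N1CCN(C(c2ccccc2)c2cccc(Cl)c2)CC1` gives 0.37 ug/mL
compound 3 `CN1CCC(C(c2ccccc2)N2CCN(C(=O)CC(c3ccccc3)c3ccccc3)CC2)CC1` gives 63.6 ug/mL

Compound 3 stands highest of the three numbers; its nearest neighbour is compound 1, with a 170-fold higher number from compound 1 to compound 3 (2.24 log units; beyond the scatter), and compound 2 lies as far off, with a 170-fold higher number from compound 2 to compound 3 (2.24 log units; beyond the scatter). The step of no change at the digits printed from compound 1 to compound 2 (within the scatter) stays within the scatter.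

Compound 4 `CN1CCC(C(c2ccc(F)cc2)N2CCN(C(=O)CC(c3ccccc3)c3ccccc3)CC2)CC1` differs from compound 3 by fluoro in place of hydrogen on an aromatic carbon, the same difference read one bond further out being phenyl to 4-fluorophenyl. Among the compounds with values here, none of the measured steps bears directly on this change: the two large steps each replace a whole chlorophenyl with 1-methylpiperidin-4-yl, and the one small step shifts a chloro within a ring; no step adds a fluoro to an otherwise unchanged compound. The expectation for this assay therefore rests on the single heavy atom entering with no ring, no donor and no acceptor, and is for a step of a 1.4-fold lower number from compound 3 to compound 4 (0.15 log units; within the scatter), at most a modest decrease and possibly none beyond the scatter. Compound 4 is estimated at 45 ug/mL, within 20 ug/mL to 100 ug/mL.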

Compound 4, solubility: 72.7 ug/mL
The estimate for compound 4 lay 1.6-fold (0.21 log units) below the measured number; low and high end bracket the measured number.
By their numbers in this assay, from the lowest: compounds 1 and 2 (each within the scatter of the next); then compounds 3 and 4 (each within the scatter of the next).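

In this assay, within the data shown here, fluoro in place of hydrogen on the six-membered aromatic ring of carbon only, para to a large group, gives a 1.1-fold higher number from compound 3 to compound 4 (0.06 log units; within the scatter) and is the first step here that adds a single atom to an otherwise unchanged compound. Earlier steps only exchanged a whole chlorophenyl or shifted a chloro within a ring, whereas this one shows that this place on the phenyl of compound 3 accepts fluoro with no difference beyond the scatter. Nothing measured here explains this outcome or links it to any property of the fluoro.

On these data alone, whether a larger group at the same place, such as chloro, methoxy or trifluoromethyl, would also stay within the scatter remains open. Fluoro at other places on this ring, and on the two phenyl rings of the other end of the molecule, is also left open.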